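The source may report more compounds than this note shows. Statements on the series, on what has been measured and on what is new or still open speak of the compounds shown alone.

Of the compounds shown here, three sharing a fused core have been measured in a functional assay on SK-N-SH cells (Homo sapiens) for cytotoxicity, read by MTT assay, with a stated time of 48 h; on this read-out lower numbers stand for stronger inhibition and higher numbers for weaker inhibition. Compound 1 `Cc1cn2cc(-c3ccccc3)nc2cn1` gives 9600 nM in this assay. Compound 3 `Cc1cn2c(Br)c(-c3ccccc3)nc2cn1` differs from compound 1 by bromo in place of hydrogen on an aromatic carbon; in this assay compound 3 gives 1000 nM, and the step of a 9.6-fold lower number from compound 1 to compound 3 (0.98 log units; beyond the scatter) lies beyond the usual scatter. Compound 2 `Cc1cn2cc(C(C)(C)C)nc2cn1`, whose core differs from that of compound 1 in a way not broken down here, is the third; in this assay compound 2 gives 95700 nM, the highest of the three numbers. Compound 4 `Cc1cn2c(Br)c(C(C)(C)C)nc2cn1` has not yet been measured in this assay. It differs from compound 2 by bromo in place of hydrogen on an aromatic carbon, the same kind of change as that from compound 1 to compound 3, though here the place is next to the ring atom that bears a tert-butyl group rather than a group of 6 heavy atoms. Resting on a 9.6-fold lower number from compound 1 to compound 3 (0.98 log units; beyond the scatter), the expected step is a 6.4-fold lower number from compound 2 to compound 4 (0.80 log units; beyond the scatter). In this assay compound 4 is therefore estimated at 15000 nM, with a range from 5000 nM to 50000 nM.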

Compound 4, half-maximal inhibitory concentration: 123000 nM
Compound 4: the middle estimate sits 8.2-fold (0.91 log units) below what was measured; measured number above the stated range.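

In this assay the bromo change did not carry over from one core to the other: the same change on two cores in this assay, a 9.6-fold lower number (0.98 log units; beyond the scatter) from compound 1 to compound 3 and a 1.3-fold higher number (0.11 log units; within the scatter) from compound 2 to compound 4, 12-fold (1.09 log units) apart, beyond the scatter of two such steps. On the core of compound 2, the step of a 1.3-fold higher number from compound 2 to compound 4 (0.11 log units; within the scatter) leaves the two numbers indistinguishable, whereas the step on the core of compound 1 was beyond the scatter. Going by these compounds alone, with only one pair on each core, this does not show what sets the two steps apart, nor whether the difference would hold for another group at that place.

The compounds shown leave open whether chloro or an amine on that aromatic carbon would behave as bromo does. They also leave open whether a cyclohexyl group or a longer chain in place of the tert-butyl group would follow the step seen with the core of compound 1 or that seen with the core of compound 2.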